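Amide side chain swap on an amino-bearing fused core

This account rests on a few compounds, and the source may have more. Where it says the series, first, only, none or still open, it means among the compounds named here.

Within the data shown here, compound 3 `Nc1nc(N2CCN(C(=O)COc3ccc(Cl)cc3)CC2)c2cc(F)sc2n1` gives 700 nM in a functional assay on cells (Lymphocyte) (a lower number here means a stronger inhibitor, a higher number a weaker inhibitor), the lowest of the two numbers measured so far. Its nearest neighbour, compound 1 `CCCCc1nc(N2CCN(C(=O)COc3ccc(Cl)cc3)CC2)c2cc(F)sc2n1`, gives 1330 nM in this assay; the two lie within the scatter (a 1.9-fold lower number from compound 1 to compound 3 (0.28 log units; within the scatter)), and no order between them is claimed. Compound 2 `CCOC(=O)c1nc(N2CCN(C(=O)COc3ccc(Cl)cc3)CC2)c2cc(F)sc2n1` reports only a limit in this assay, > 10000 nM, as noted in the limit of > 10000 nM in this assay, at which 1 of the 3 values shown sits. The steps of an at least 7.5-fold higher number from compound 1 to compound 2 (0.87 log units; beyond the scatter) and an at least 14-fold lower number from compound 2 to compound 3 (1.15 log units; beyond the scatter) therefore rest on a limit rather than a number, yet both lie beyond the scatter. All three measured steps change the substituent on an aromatic carbon of the shared core; none touches the amide side chain.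

Compound 4 `Nc1nc(N2CCN(C(=O)CCc3ccccc3)CC2)c2cc(F)sc2n1` differs from compound 3 in that side chain: benzyl in place of 4-chlorophenoxy on a saturated chain carbon bound to a carbonyl carbon. Among the measured compounds shown here, no measured step bears on this change, and the core of compound 3 with its 700 nM is the only anchor. A modest weakening is expected, estimated as a 2.3-fold higher number from compound 3 to compound 4 (0.36 log units; beyond the scatter). Compound 4 is expected at 1600 nM in this assay, within 400 nM to 6500 nM.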

Compound 4, half-maximal inhibitory concentration: 6990 nM
For compound 4 the middle estimate is 4.4-fold (0.64 log units) below the measured one; the whole stated range lies below it.
By their numbers in this assay, from the lowest: compounds 3 and 1 (each within the scatter of the next); then compound 4. At a limit, above all of these: compound 2.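

Changing the amide side chain moves the number in this assay well beyond the scatter, with benzyl in place of 4-chlorophenoxy giving a 10-fold higher number from compound 3 to compound 4 (1.00 log units; beyond the scatter) on the same amino-bearing core. Among these compounds, the earlier steps all lay on an aromatic carbon of the shared core, so this is the first sign that the side chain also matters, and of these two side chains the (4-chlorophenoxy)methyl form keeps the lower number. Nothing shown here gives a reason for this step.

From the compounds shown here alone, the change removes the chlorine and the oxygen together, so the share of each in the step stays open. Also open, going by these compounds, is whether a phenoxy side chain without chlorine, or an amine or a carboxylic acid on that chain, would hold the number of compound 3.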